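The compounds below may be only part of what the source reports. "The series", "measured", "known", "first", "only" and "open" are said of these compounds alone.

In a functional assay on Malme-3M cells (Homo sapiens) for inhibition, read by sulforhodamine B assay, with a stated time of 48 h (a lower number here means a stronger inhibitor of growth, a higher number a weaker inhibitor of growth), compound 1 `COc1ccc(-c2cc(/C=C/C(=O)c3ccc(N)cc3)[nH]n2)cc1` gives 2180 nM, and compound 2 `COc1ccc(C(=O)/C=C/c2cc(-c3cc(OC)c(OC)c(OC)c3)n[nH]2)cc1OC` gives 1990 nM; these two numbers lie within the scatter of each other. How the cores of compound 1 and compound 2 differ is not broken down here. Compound 3 `COc1ccc(-c2cc(/C=C/C(=O)c3ccc(N)cc3)[nH]n2)cc1OC` gives 6720 nM. The change from compound 1 to compound 3 is methoxy in place of hydrogen on an aromatic carbon, and it made a step of a 3.1-fold higher number from compound 1 to compound 3 (0.49 log units; beyond the scatter). Compound 4 `COc1cc(C(=O)/C=C/c2cc(-c3cc(OC)c(OC)c(OC)c3)n[nH]2)cc(OC)c1OC` has not yet been measured. It arises from compound 2 through (methoxy in place of hydrogen on an aromatic carbon), the same kind of change, though here the place is also meta to a methoxy group. For compound 4 the estimated step is a 3.0-fold higher number from compound 2 to compound 4 (0.48 log units; beyond the scatter), which rests on the measured step of a 3.1-fold higher number from compound 1 to compound 3 (0.49 log units; beyond the scatter). Compound 4 is therefore expected to give 6000 nM, with a likely range from 3000 nM to 12000 nM.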

Compound 4, concentration for 50% growth inhibition: 1860 nM
Estimate against measurement, compound 4: 3.2-fold (0.51 log units) above; measured number outside the range, below it.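

In this assay, methoxy in place of hydrogen on an aromatic carbon made a 1.1-fold lower number from compound 2 to compound 4 (0.03 log units; within the scatter), and this step does not match the earlier one: the same change on two cores in this assay, a 3.1-fold higher number (0.49 log units; beyond the scatter) from compound 1 to compound 3 and a 1.1-fold lower number (0.03 log units; within the scatter) from compound 2 to compound 4, 3.3-fold (0.52 log units) apart, beyond the scatter of two such steps In this series, then, the size of the step measured on one core did not hold on the other, so it cannot simply be carried across. This does not show which difference between the cores matters, as the two pairs also differ in the surroundings of the new methoxy group and there are only two of them.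

The compounds shown leave open how a hydroxyl or an ethoxy group would behave at this place on either core. They also leave open which of the two steps a third core would follow.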